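The source may report more compounds than this note shows. Statements on the series, on what has been measured and on what is new or still open speak of the compounds shown alone.

Measured so far:
compound 1 `O=C(/C=C1\CCc2cc(Cl)c(F)cc21)NC1CC1`: 27%
compound 2 `CNC(=O)/C=C1\CCc2cc(Cl)c(F)cc21`: 22%

In a functional assay on the whole organism for inhibition, with Rattus norvegicus as the target, at a dose of 20 mg/kg by the oral route (a higher number here means more inhibition at the dose given (going by the name of the read-out), a lower number less inhibition), compound 1 gives 27% and compound 2 gives 22%. The two numbers sit within the scatter of each other, as the step of a number 5 percentage points lower from compound 1 to compound 2 (within the scatter) shows, so neither compound can be set apart from the other on this assay.

Compound 3 `NC(=O)/C=C1\CCc2cc(Cl)c(F)cc21` is the next step from compound 2: hydrogen in place of methyl on an amide-type nitrogen. Going by the values given here, the only measured step that bears on it is the cut at the same amide-type nitrogen, a number 5 percentage points lower from compound 1 to compound 2 (within the scatter), which stayed within the scatter. Taking away the remaining methyl is a change of the same kind at the same place, and nothing in the two numbers points to a move in either direction. For compound 3 the expected step is therefore no change at the digits printed from compound 2 to compound 3 (within the scatter), nothing beyond the scatter. Compound 3 is estimated to give 22%, with a range from 8% to 38% in this assay.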

Compound 3, a percentage reported as inhibition, in the whole organism at one dose (the size of the read-out at that dose, not a potency): 19%
Beside the measured number, compound 3's estimate is 3 percentage points above it; measured number inside the range.
By their numbers in this assay, from the lowest: compounds 3, 2 and 1 (each within the scatter of the next).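

In this assay, taking the amide-type nitrogen down to a bare hydrogen gives a number 3 percentage points lower from compound 2 to compound 3 (within the scatter) and a number 8 percentage points lower from compound 1 to compound 3 (within the scatter) as its two readings. Hydrogen, methyl and cyclopropyl on this nitrogen therefore cannot be set apart at this dose, and even hydrogen in place of cyclopropyl, the ring-bearing group, stays inside the usual scatter. No supporting measurement bears on why this position reads so flat.

Still open, on these data alone, is whether a longer chain, a benzyl group or a chain ending in an amine on this nitrogen would move the number beyond the scatter. Also open, as far as these compounds go, is whether a carboxylic acid in place of the whole amide would read any differently on the shared core.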